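Pyrimidine series: swap of the amine substituent, expected response

The compounds below may be only part of what the source reports. "The series", "measured", "known", "first", "only" and "open" are said of these compounds alone.

Working notes on three measured compounds and one to come. Compound 1 `COc1ccc(CN2CCc3nc(-c4ccccn4)nc(N4CCN(CCN(C)C)CC4)c3C2)cc1` is reported in an assay on A549 cells with Cystic fibrosis transmembrane conductance regulator variant F508del (Homo sapiens) as the target, read by fluorescence, with a stated time of 25 min (a higher number here means a larger maximal response, a lower number a smaller maximal response), as "not active" (no number reported), with no number given. Compound 2 `COc1ccc(CN2CCc3nc(-c4ccccn4)nc(N4CCC(C(N)=O)CC4)c3C2)cc1` is likewise reported in this assay as "not active" (no number reported), again without a number. Within the data shown here, compound 3 `COc1ccc(CN2CCc3nc(-c4ccccn4)nc(N4CCN(CC(N)=O)CC4)c3C2)cc1` is the only member with a figure: in this assay compound 3 reaches 36.8%. It therefore stands alone on the numbers shown, with two further entries beside it that carry no value, so no step between measured compounds can be stated and no pattern can be drawn from the series.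

Compound 4 `CCN(C(C)=O)C1CCN(c2nc(-c3ccccn3)nc3c2CN(Cc2ccc(OC)cc2)CC3)C1` is the next entry, not yet measured. It differs from compound 3 at a single position: 3-(acetyl(ethyl)amino)pyrrolidin-1-yl in place of 4-(carbamoylmethyl)piperazin-1-yl on an aromatic carbon. The replacement brings a group with no hydrogen-bond donor and one fewer acceptor in place of the carbamoylmethyl-bearing piperazine, and the two amine-substituted compounds without a number give no support for the new group. A downward step is therefore expected, of moderate size, and the estimate is a number 16.8 percentage points lower from compound 3 to compound 4 (beyond the scatter). For compound 4 in this assay the expected value is 20%, with a range from 0% to 40%, and a real chance that only a limit is reported.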

Compound 4, largest response reached (Emax), in percent of the reference or control that the assay uses: "not active" (no number reported)
Nothing numeric was reported for compound 4; the estimate stays without a comparison.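

In this assay, among these compounds, compound 4 is reported as "not active" (no number reported), so no step from compound 3 to compound 4 can be read. The compounds shown leave open whether any replacement of the 4-(carbamoylmethyl)piperazin-1-yl group of compound 3 retains a measurable response. No measured evidence bears on this result.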